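The compounds below may be only part of what the source reports. "The series", "measured", "known", "first", "only" and "open" are said of these compounds alone.

Series notes: two urea analogues measured, one pending. Compound 1 `O=C(NCCCCC(c1ccc(F)cc1)c1ccc(F)cc1)Nc1ccc(Cl)c(C(F)(F)F)c1` gives 90% in an ADME assay on isolated protein for inhibition of sodium-dependent dopamine transporter (Homo sapiens), tested at 10 uM; on this read-out lower numbers stand for less inhibition and higher numbers for more inhibition at the one concentration tested (going by the name of the read-out). Going by the values given here, compound 2 `CC(=O)Nc1cc(NC(=O)NCCCCC(c2ccc(F)cc2)c2ccc(F)cc2)ccc1Cl` gives 76% in this assay, the lower of the two numbers; the single measured step, a number 14 percentage points lower from compound 1 to compound 2 (beyond the scatter), accounts for this gap, which lies beyond the scatter. Compound 3 `Cc1cc(Cl)ccc1NC(=O)NCCCCC(c1ccc(F)cc1)c1ccc(F)cc1` has not yet been measured in this assay. Its change from compound 2 is 4-chloro-2-methylphenyl in place of 3-acetamido-4-chlorophenyl on an amide-type nitrogen. This removes the acetamido that the measured step introduced, keeps the chlorine and adds a methyl, so that step is the one that bears on the case, although it says nothing about the methyl. Given the drop of a number 14 percentage points lower from compound 1 to compound 2 (beyond the scatter), compound 3 is expected to recover much of that loss, an estimated step of a number 8 percentage points higher from compound 2 to compound 3 (within the scatter) upward. Compound 3 is therefore estimated at 84% in this assay, within 68% to 96%.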

Compound 3, a percentage reported as inhibition, at one concentration (the size of the read-out at that concentration, not a potency): 58%
The estimate for compound 3 lay 26 percentage points above the measured number; the measured number lies below the stated range.
By their numbers in this assay, from the lowest: compound 3; then compound 2; then compound 1.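

On the amide-type nitrogen, 4-chloro-2-methylphenyl in place of 3-acetamido-4-chlorophenyl gives a number 18 percentage points lower from compound 2 to compound 3 (beyond the scatter) in this assay, so losing the acetamido does not by itself bring the read-out back towards that of compound 1. Set against the trifluoromethyl-bearing group, 4-chloro-2-methylphenyl in place of 4-chloro-3-(trifluoromethyl)phenyl gives a number 32 percentage points lower from compound 1 to compound 3 (beyond the scatter), which leaves compound 3 lowest of the three and shows that the aryl group at this place can shift the number by much more than the first step suggested. Nothing available accounts for the size or direction of these steps.

In compound 3 the methyl enters as the acetamido leaves, so their separate contributions cannot be read. Where a nitrile in place of the trifluoromethyl of compound 1 would fall remains open, as does the effect of an amine or a carboxylic acid on that aromatic ring.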